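Chloro on the phenoxy tail of compound 1

This account rests on a few compounds, and the source may have more. Where it says the series, first, only, none or still open, it means among the compounds named here.

compound 1, `NC1=NC2(CCOCC2)N(OCCCOc2ccccc2)C(N)=N1`: 86.1 nM
compound 2, `CC(C)(C)c1ccc(OCCCON2C(N)=NC(N)=NC23CCSCC3)cc1`: "not determined" (no result reported)

Among the compounds with values here, in an assay on isolated protein for inhibition of Dihydrofolate reductase (Homo sapiens), read by spectrophotometry, using NADPH, with stated times of 5 s and 6 min (a higher number here means a weaker inhibitor, a lower number a stronger inhibitor), compound 1 gives 86.1 nM, the only number in this set; compound 2 gives "not determined" (no result reported). Compound 3, `NC1=NC2(CCOCC2)N(OCCCOc2ccc(Cl)cc2)C(N)=N1`, differs from compound 1 by chloro in place of hydrogen on an aromatic carbon, para to a large group. Within the data shown here, no step between measured compounds is available, so the size of such a change is untested. The expected change is a 1.4-fold lower number from compound 1 to compound 3 (0.16 log units; within the scatter), a slight gain at most, not beyond the scatter. Compound 3 is estimated at 60 nM, range 20 nM to 200 nM.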

Compound 3, half-maximal inhibitory concentration: 33.6 nM
Beside the measured number, compound 3's estimate is 1.8-fold (0.25 log units) above it; the range from low to high includes it.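

In this assay, within the data shown here, the 4-chlorophenoxy tail gives the first measured step at this position (a 2.6-fold lower number from compound 1 to compound 3 (0.41 log units; beyond the scatter)). Chloro in place of hydrogen on the aromatic carbon, para to a large group, is therefore tolerated and brings a modest gain over the unsubstituted phenoxy tail. No measurement at hand accounts for this gain.

As far as these compounds go, whether the gain is specific to chloro remains open, as fluoro, methoxy or a carboxylic acid at the same place would be needed to show it. Also open, from the compounds shown here alone, is whether it persists with a longer chain in the tail.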